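The compounds below may be only part of what the source reports. "The series", "measured", "known", "first", "only" and "open" are said of these compounds alone.

Measured compounds in a functional assay on MGC-803 cells (Homo sapiens) for inhibition, read by MTT assay, with a stated time of 72 h; a higher number here means a weaker inhibitor, a lower number a stronger inhibitor:
compound 1 `C#CCSc1nc(Nc2ccccc2)c2ccncc2n1` gives 16200 nM
compound 2 `C#CCSc1nc(Nc2ccc(C)cc2)c2ccncc2n1` gives 8090 nM
compound 3 `C#CCSc1nc(Nc2ccc(F)cc2)c2ccncc2n1` gives 15800 nM

All three share one core and differ only in the group on the nitrogen on the aromatic ring. The steps among them are small: a 2.0-fold lower number from compound 1 to compound 2 (0.30 log units; within the scatter), a 1.0-fold lower number from compound 1 to compound 3 (0.01 log units; within the scatter) and a 2.0-fold higher number from compound 2 to compound 3 (0.29 log units; within the scatter), each within the scatter. Compound 3 therefore sits in the same band as compound 1 and compound 2; nothing separates the three beyond repeat variation.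

Compound 4 `C#CCSc1nc(Nc2ccccc2Cl)c2ccncc2n1` is not yet measured. Relative to compound 3 the change is 2-chlorophenyl in place of 4-fluorophenyl on a nitrogen on an aromatic ring. Among the measured compounds shown here, no measured pair exchanges one substituted phenyl for 2-chlorophenyl, so the earlier steps bear on this change only indirectly. What they show is that hydrogen, methyl or fluoro on that phenyl moved this assay by less than the scatter in every case. On that basis the expected step for compound 4 in this assay is a 1.1-fold lower number from compound 3 to compound 4 (0.02 log units; within the scatter), that is none beyond the scatter. Compound 4 is expected to give 15000 nM, with a range of 5000 nM to 45000 nM. This rests on compound 3 giving 15800 nM and on the widest change seen so far being a 2.0-fold lower number from compound 1 to compound 2 (0.30 log units; within the scatter).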

Compound 4, half-maximal inhibitory concentration: 27600 nM
The estimate for compound 4 lay 1.8-fold (0.26 log units) below the measured number, and the stated range covers the measured number.
By their numbers in this assay, from the lowest: compounds 2, 3, 1 and 4 (each within the scatter of the next, the first and the last beyond it).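

In this assay the group on the nitrogen gives its first step beyond the scatter (a 3.4-fold higher number from compound 2 to compound 4 (0.53 log units; beyond the scatter)), a modest one, with 2-chlorophenyl in place of 4-methylphenyl. The other two steps stay within the scatter (a 1.7-fold higher number from compound 1 to compound 4 (0.23 log units; within the scatter)) and (a 1.7-fold higher number from compound 3 to compound 4 (0.24 log units; within the scatter)), so among the compounds shown 2-chlorophenyl separates from 4-methylphenyl only, and not from phenyl or 4-fluorophenyl. The data shown offer no measured explanation for that one separation.

Compound 2 and compound 4 differ both in the substituent and in where it sits on the phenyl, so the compounds shown leave open whether the step belongs to the chloro group or to its place on the ring. Also open is how this assay would respond to an amine or a carboxylic acid on that phenyl, since every group shown on the nitrogen is a phenyl carrying hydrogen, methyl, fluoro or chloro.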